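Adding isopropoxy to compound 2: working notes

The source may report more compounds than this note shows. Statements on the series, on what has been measured and on what is new or still open speak of the compounds shown alone.

Measured compounds, both values being limits:
- compound 1 `COc1cc(-n2ncnc2-c2ccc(C)cc2)cc(OC)c1OC` gives > 10000 nM as a limit
- compound 2 `COc1cc(-n2ncnc2-c2ccccc2)cc(OC)c1OC` gives > 10000 nM as a limit

In a functional assay on K562 cells (Homo sapiens) for antiproliferative activity, read by MTT assay, with a stated time of 72 h (on this read-out lower numbers stand for stronger inhibition and higher numbers for weaker inhibition), compound 2 stands at > 10000 nM as a limit and has no number. Among the compounds with values here, the whole series so far is the limit of > 10000 nM in this assay, at which 2 of the 2 values shown sit, and offers no graded value. Within the data shown here, the one measured step, a step that the two limits leave unreadable from compound 1 to compound 2, therefore gives no size to carry forward.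

Going on to compound 3 `COc1cc(-n2ncnc2-c2ccc(OC(C)C)cc2)cc(OC)c1OC`, the change is isopropoxy in place of hydrogen on an aromatic carbon and it lies on an aromatic carbon of a six-membered aromatic ring of carbon only, para to a large group. Isopropoxy in place of hydrogen has no measured precedent in this set. Neither compound 1 nor compound 2 shows a readable response in this assay to a change on an aromatic carbon, so a result close to the same limit is the likeliest outcome, with any movement expected toward stronger inhibition. The estimated step is an at least 1.2-fold lower number from compound 2 to compound 3 (0.09 log units; that floor lies within the scatter) and it is expected to be small. For compound 3 the estimate is 8000 nM with an expected range from 1000 nM to 20000 nM as the working figures.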

Compound 3, half-maximal inhibitory concentration: 800 nM
For compound 3 the middle estimate is 10-fold (1.00 log units) above the measured one; measured number outside the range, below it.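

In this assay, the aromatic carbon para to a large group now gives a readable response, which neither earlier compound showed: isopropoxy in place of hydrogen gives an at least 12-fold lower number from compound 2 to compound 3 (1.09 log units; beyond the scatter). Isopropoxy in place of methyl on the same carbon gives an at least 12-fold lower number from compound 1 to compound 3 (1.09 log units; beyond the scatter), so in this series the response follows isopropoxy, and the presence of methyl alone does not produce it. Both steps are floors and not full sizes, because the two starting compounds carry only a limit and no number: the limit of > 10000 nM in this assay, at which 2 of the 3 values shown sit.

The compounds shown do not separate the contribution of the oxygen from that of the branched carbons of isopropoxy, and whether ethoxy, a longer chain such as butoxy, or a plain isopropyl group on the same carbon would give a similar step remains open. Also open, as far as these compounds go, is how an amine or a carboxylic acid would behave on this carbon, and whether isopropoxy would give any step on another carbon of the same ring.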